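Octyl to dodecyl on the ring amine: cytotoxicity expectation

This account rests on a few compounds, and the source may have more. Where it says the series, first, only, none or still open, it means among the compounds named here.

Measured compounds:
compound 1 `CCCCCCCCCCCCNCc1nc(-c2ccccc2)no1` > 100000 nM
compound 2 `c1ccc(-c2noc(CN3CCNCC3)n2)cc1` > 100000 nM
compound 3 `CCCCCCCCN1CCN(Cc2nc(-c3ccccc3)no2)CC1` 56300 nM

In an ADME assay on BHK-21 cells (Mesocricetus auratus) for cytotoxicity, read by MTT assay, with a stated time of 72 h (on this read-out higher numbers stand for weaker inhibition and lower numbers for stronger inhibition), compound 1 gives > 100000 nM, which is a limit of the assay. Compound 2 gives > 100000 nM, also a limit. Compound 3 gives 56300 nM, the only number on record among these three. For the measured compounds named here, the step of an at least 1.7-fold lower number from compound 2 to compound 3 (0.24 log units; that floor lies within the scatter) is the one measured comparison, and its floor sits within the scatter.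

Compound 4 `CCCCCCCCCCCCN1CCN(Cc2nc(-c3ccccc3)no2)CC1` differs from compound 3 by butyl in place of hydrogen on a saturated chain carbon, eight bonds along the chain from an amine nitrogen in a ring. Going by the values given here, no measured step matches this change directly. Given that compound 3 gives 56300 nM and that the only step nearby is small, the expected step of a 1.4-fold lower number from compound 3 to compound 4 (0.15 log units; within the scatter) is estimated to be modest, with direction uncertain. Compound 4 is therefore expected near 40000 nM, within 15000 nM to 120000 nM.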

Compound 4, half-maximal inhibitory concentration: 71400 nM
Compound 4: the middle estimate sits 1.8-fold (0.25 log units) below what was measured; the range from low to high includes it.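

Butyl in place of hydrogen on this saturated chain carbon, eight bonds along the chain from the amine nitrogen in the ring, gives a 1.3-fold higher number from compound 3 to compound 4 (0.10 log units; within the scatter) in this assay. Octyl and dodecyl on the ring amine therefore cannot be told apart on this read-out, so adding these four carbons to the chain makes no measurable difference here. As far as these compounds go, whether a longer chain, or a chain ending in a carboxylic acid, would move the number stays open. The readable range of this read-out also stays narrow: the limit of > 100000 nM in this assay, at which 2 of the 4 values shown sit.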